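This account rests on a few compounds, and the source may have more. Where it says the series, first, only, none or still open, it means among the compounds named here.

Of the compounds shown here, three have been tested in an assay on isolated protein for inhibition of cathepsin S (Homo sapiens), read by fluorescence, with a stated time of 20 min; on this read-out higher numbers stand for weaker inhibition and lower numbers for stronger inhibition. Compound 2 `N#CC1(NC(=O)[C@@H]2C[C@@H](S(=O)(=O)c3ccccc3)C[C@H]2C(=O)N2CC3CCC(C2)O3)CC1` gives 1 nM, the lowest number of the three and so the strongest inhibitor here. Compound 3 `N#CC1(NC(=O)[C@@H]2C[C@@H](S(=O)(=O)c3ccccc3)C[C@H]2C(=O)N2CC3(COC3)C2)CC1` gives 3 nM, and compound 1 `N#CCNC(=O)[C@@H]1C[C@@H](S(=O)(=O)CC2CC2)C[C@H]1C(=O)N1CCOCC1` gives 230 nM. The next compound, compound 4 `CN(C)C(=O)[C@@H]1C[C@H](S(=O)(=O)c2ccccc2)C[C@H]1C(=O)NC1(C#N)CC1`, differs from compound 2 as follows: a group of 3 heavy atoms (2 carbon, 1 nitrogen; no ring) in place of a group of 8 heavy atoms (6 carbon, 1 nitrogen, 1 oxygen; one five-membered non-aromatic ring with 1 hetero atom, one six-membered non-aromatic ring with 2 hetero atoms), on a carbonyl carbon. Among the measured compounds shown here, the one step that bears on this change is the one at the same carbonyl carbon, which gave a 3.0-fold higher number from compound 2 to compound 3 (0.48 log units; beyond the scatter) when a smaller ring-bearing group replaced the original one. Compound 4 goes further and removes the rings altogether, so a larger loss is expected, namely a 15-fold higher number from compound 2 to compound 4 (1.18 log units; beyond the scatter). Compound 4 is therefore estimated at 15 nM, with a likely range from 4 nM to 60 nM.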

Compound 4, half-maximal inhibitory concentration: 6 nM
For compound 4 the middle estimate is 2.5-fold (0.40 log units) above the measured one, within the range that was stated.
By their numbers in this assay, from the lowest: compound 2; then compounds 3 and 4 (each within the scatter of the next); then compound 1.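

At this carbonyl carbon, the group needs no ring for inhibition to stay strong in this assay: changing to dimethylamino gives a 6.0-fold higher number from compound 2 to compound 4 (0.78 log units; beyond the scatter). Set against the group with two four-membered rings, the same change gives a 2.0-fold higher number from compound 3 to compound 4 (0.30 log units; within the scatter), so these two groups cannot be told apart here. No evidence is available to explain either step. On these data alone, it remains open how a longer chain such as diethylamino, or a group carrying a carboxylic acid, would fare at this position. Also open, as far as these compounds go, is whether dimethylamino would behave the same way on the core of compound 1.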